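The source may report more compounds than this note shows. Statements on the series, on what has been measured and on what is new or still open speak of the compounds shown alone.

Series notes, aryl substituent on the shared core

Values in a functional assay on KBVIN cells (Homo sapiens) for antiproliferative activity, read by sulforhodamine B assay, with a stated time of 3 days; on this read-out lower numbers stand for an effect already at smaller amounts and higher numbers for an effect only at larger amounts of compound:
compound 1 `CCCCc1ccc(-c2cc(=O)c3c(o2)C(CC)(CC)C(=O)C(CC)=C3O)cc1`: 37 uM
compound 2 `CCCOc1ccc(-c2cc(=O)c3c(o2)C(CC)(CC)C(=O)C(CC)=C3O)cc1`: 29.2 uM
compound 3 `CCC1=C(O)c2c(oc(-c3ccc(Br)cc3)cc2=O)C(CC)(CC)C1=O`: 15.7 uM

Among these three numbers compound 3 has the lowest. The step of a 1.9-fold lower number from compound 2 to compound 3 (0.27 log units; within the scatter) stays within the scatter, so the two cannot be ordered; the step of a 2.4-fold lower number from compound 1 to compound 3 (0.37 log units; beyond the scatter) is a modest one beyond the scatter. The step of a 1.3-fold lower number from compound 1 to compound 2 (0.10 log units; within the scatter) is within the scatter.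

Compound 4 `CCC1=C(O)c2c(oc(-c3ccc(C)c(F)c3)cc2=O)C(CC)(CC)C1=O` is not yet measured. Change from compound 3: 3-fluoro-4-methylphenyl in place of 4-bromophenyl on an aromatic carbon. Among the compounds with values here, no measured step in this set exchanges one halogen for another halogen plus a methyl on the same ring, so the bearing of the measured steps is indirect: all three aryl variants fall within a narrow band, and the only step beyond the scatter, a 2.4-fold lower number from compound 1 to compound 3 (0.37 log units; beyond the scatter), is itself modest. A step in this assay of no more than the usual scatter is therefore expected for compound 4, in either direction.

Estimate for compound 4 in this assay: 20 uM, range 8 uM to 50 uM, corresponding to an expected step of a 1.3-fold higher number from compound 3 to compound 4 (0.11 log units; within the scatter).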

Compound 4, concentration for half-maximal effect: 2.95 uM
For compound 4 the middle estimate is 6.8-fold (0.83 log units) above the measured one; the whole stated range lies above it.
By their numbers in this assay, from the lowest: compound 4; then compounds 3, 2 and 1 (each within the scatter of the next, the first and the last beyond it).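

At the aromatic carbon next to the ring oxygen, 3-fluoro-4-methylphenyl in place of 4-bromophenyl gives, in this assay, a 5.3-fold lower number from compound 3 to compound 4 (0.73 log units; beyond the scatter) and places compound 4 lowest of the four numbers. The earlier aryl groups each carry one substituent and span no more than a 2.4-fold lower number from compound 1 to compound 3 (0.37 log units; beyond the scatter), so this position can shift the number further than those compounds showed, and the first ring here with two substituents does so. Nothing measured in this set bears on why the step is this large.

The compounds shown do not separate the fluoro and methyl contributions, as neither 3-fluorophenyl nor 4-methylphenyl is among them. Also open is how an amine or a carboxylic acid on this ring would compare with the groups shown.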